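Lengthening the carbamate chain in a chlorinated amide series

This account rests on a few compounds, and the source may have more. Where it says the series, first, only, none or still open, it means among the compounds named here.

Of the compounds shown here, three sharing one core have been measured in a physicochemical assay for lipophilicity; on this read-out lower numbers stand for lower lipophilicity and higher numbers for higher lipophilicity. Compound 1 `CCCCCNC(=O)Oc1ccc(Cl)cc1C(=O)Nc1cccc(Cl)c1` gives 5.11 in this assay. Compound 2 `CCCCCCNC(=O)Oc1ccc(Cl)cc1C(=O)Nc1cccc(Cl)c1` carries methyl in place of hydrogen on a saturated chain carbon, five bonds along the chain from an amide-type nitrogen; in this assay compound 2 gives 5.53, which is a number 0.42 log units higher from compound 1 to compound 2 (beyond the scatter). Compound 3 `CCCCCCNC(=O)Oc1ccc(Cl)cc1C(=O)Nc1ccc(Cl)cc1` differs from compound 2 in another part of the molecule, a step of no change at the digits printed from compound 2 to compound 3 (within the scatter), and in this assay compound 3 gives 5.53. The difference between the cores of compound 1 and compound 3 is not broken down here.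

Compound 4 `CCCCCCCNC(=O)Oc1ccc(Cl)cc1C(=O)Nc1ccc(Cl)cc1` is not yet measured. Against compound 3 it carries methyl in place of hydrogen on a saturated chain carbon, six bonds along the chain from an amide-type nitrogen. Among the measured compounds shown here, this is the same kind of change as the one from compound 1 to compound 2, but not the same: there the place was five bonds along the chain from an amide-type nitrogen, here it is six. Only one earlier example of this kind exists among these compounds, so the expectation rests on it alone. For the measured compounds named here, for compound 4 a step of about a number 0.42 log units higher from compound 3 to compound 4 (beyond the scatter) is expected because the single earlier step of the same kind read a number 0.42 log units higher from compound 1 to compound 2 (beyond the scatter). Compound 4 is therefore estimated at 5.95, with a likely range from 5.7 to 6.2.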

Compound 4, partition coefficient: 5.94
For compound 4 the middle estimate is 0.01 log units above the measured one; the measured number falls inside the stated range.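

In this assay the added methyl on a saturated chain carbon, six bonds along the chain from an amide-type nitrogen, gives a number 0.41 log units higher from compound 3 to compound 4 (beyond the scatter) and so stands close to the earlier step of a number 0.42 log units higher from compound 1 to compound 2 (beyond the scatter) in size. The same kind of change therefore kept much the same size when carried from the core of compound 1 to the core of compound 3 and one place further along the chain, but two steps show agreement in this one pair and no general rule, and since the core and the place both differ, their separate contributions cannot be told apart. Nothing available here explains the size of either step.

From the compounds shown here alone, whether the same size would hold on a longer chain, or if an amine or a carboxylic acid stood in place of the added methyl, remains open. Also open, going by these compounds, is whether the change from compound 3 to compound 4 would read the same if made on compound 2.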